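The compounds below may be only part of what the source reports. "The series", "measured", "known", "first", "only" and "open" are said of these compounds alone.

Of the compounds shown here, three built on a shared core have been measured in an assay on isolated protein for binding affinity to adenosine receptor A1 (Bos taurus); on this read-out lower numbers stand for stronger inhibition and higher numbers for weaker inhibition. Compound 1 `OCCNc1nc(-c2ccccc2)nc2c1nnn2Cc1ccccc1` gives 38000000 nM. Compound 2 `COc1ccc(C(=O)Nc2nc(-c3ccccc3)nc3c2nnn3Cc2ccccc2Cl)cc1` gives 20000000 nM. Compound 3 `Clc1ccccc1Cn1nnc2c(NC3CCCC3)nc(-c3ccccc3)nc21` gives 9000000 nM, the lowest of the three numbers, with compound 2 nearest and compound 1 furthest away. Among the measured compounds shown here, the only step computed between measured compounds is a 2.2-fold lower number from compound 2 to compound 3 (0.35 log units; beyond the scatter), a change at the same nitrogen that compound 4 alters. Compound 4 `OCCNc1nc(-c2ccccc2)nc2c1nnn2Cc1ccccc1Cl` differs from compound 3 by 2-hydroxyethyl in place of cyclopentyl on a nitrogen on an aromatic ring. For the measured compounds named here, no measured step covers this exact exchange, so the expectation rests on a comparison: compound 1 carries the same 2-hydroxyethyl group and differs from compound 4 in one place only, and compound 1 gives 38000000 nM while compound 3 gives 9000000 nM. Compound 4 is therefore expected to land between those two values, a weakening of a 2.8-fold higher number from compound 3 to compound 4 (0.44 log units; beyond the scatter) in this assay. The estimate for compound 4 is 25000000 nM, with a range from 8000000 nM to 80000000 nM.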

Compound 4, inhibition constant: 116000000 nM
The estimate for compound 4 lay 4.6-fold (0.67 log units) below the measured number; the measured number lies above the stated range.
By their numbers in this assay, from the lowest: compound 3; then compounds 2 and 1 (each within the scatter of the next); then compound 4.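

On the nitrogen on the aromatic ring, 2-hydroxyethyl in place of cyclopentyl gives the largest step seen so far in this assay, a 13-fold higher number from compound 3 to compound 4 (1.11 log units; beyond the scatter), so this position clearly responds to what it carries. Among the compounds shown here, the same group also compares poorly with (4-methoxyphenyl)carbonyl, a 5.8-fold higher number from compound 2 to compound 4 (0.76 log units; beyond the scatter), and the new pair gives the first reading at a second place, where chloro in place of hydrogen on an aromatic carbon gives a 3.1-fold higher number from compound 1 to compound 4 (0.48 log units; beyond the scatter). Nothing given here explains the direction or size of these steps.

The compounds shown leave open whether the loss follows the hydroxyl oxygen or the missing ring, which a plain ethyl, a 2-methoxyethyl or a cyclohexyl group on that nitrogen would help to separate. They also leave open whether chloro has the same effect when cyclopentyl sits on the nitrogen.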